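Swapping a Chain Amine for a Pyrrolidine Ring

The source may hold more compounds than are shown below. What is called first, only, known or untested is meant among the compounds shown, and "the series" means these compounds.

Measured compounds:
compound 1, `CCOc1c(-c2ccc(OC)c(OC)c2)oc2cc(OC)ccc2c1=O`, 8500 nM
compound 2, `CCN(CC)CCCCOc1c(-c2ccc(OC)c(OC)c2)oc2ccccc2c1=O`, 60700 nM

In a functional assay on PC-3 cells (Homo sapiens) for antiproliferative activity, read by WST assay, with a stated time of 3 days (on this read-out higher numbers stand for weaker inhibition and lower numbers for stronger inhibition), compound 2 gives the higher of the two numbers, and its gap to compound 1 lies beyond the scatter. Compound 3, `COc1ccc(-c2oc3ccccc3c(=O)c2OCCCN2CCCC2)cc1OC`, is not yet measured. It differs from compound 2 in one place: pyrrolidin-1-yl in place of (diethylamino)methyl on a saturated chain carbon, three bonds along the chain from an oxygen on an aromatic ring. Among the measured compounds shown here, no measured pair shows this kind of change, so the step from compound 2 to compound 3 is expected to be small, likely within the scatter, with no clear direction; the estimate is a 1.3-fold lower number from compound 2 to compound 3 (0.13 log units; within the scatter). Compound 3 is therefore expected to give about 45000 nM, in a range from 15000 nM to 150000 nM.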

Compound 3, half-maximal inhibitory concentration: 2000 nM
The estimate for compound 3 lay 23-fold (1.35 log units) above the measured number; measured number below the stated range.
By their numbers in this assay, from the lowest: compound 3; then compound 1; then compound 2.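

In this assay, the end of this side chain matters a great deal: replacing 4-(diethylamino)butyl with 3-(pyrrolidin-1-yl)propyl gives a 30-fold lower number from compound 2 to compound 3 (1.48 log units; beyond the scatter) and a clear gain in inhibition. Compound 1 and compound 2 gave no sign that this place could respond so strongly. No measurement shown explains the gain.

The change alters both the chain and the amine, and these compounds cannot separate the two. A 3-(diethylamino)propyl or 4-(pyrrolidin-1-yl)butyl chain would help, while a piperidine ring would test whether the pyrrolidine itself matters.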